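Thiourea analogue with 2-hydroxyphenyl: expected activity

This account rests on a few compounds, and the source may have more. Where it says the series, first, only, none or still open, it means among the compounds named here.

Compound 1 `COc1cc(/C=C/C(=O)C2=C(/C=C/c3ccc(O)c(OC)c3)NC(=O)NC2c2ccc(C)cc2)ccc1O` gives 46% in a functional assay, with a stated time of 20 min, tested at 50 uM; on this read-out higher numbers stand for a stronger effect at the one concentration tested and lower numbers for a weaker effect. Compound 2 `COc1cc(/C=C/C(=O)C2=C(/C=C/c3ccc(O)c(OC)c3)NC(=O)NC2c2ccccc2O)ccc1O` gives 88.9% in the same read-out. Among the measured compounds shown here, the two differ by one change, (2-hydroxyphenyl in place of 4-methylphenyl on a saturated ring carbon), and the step of a number 42.9 percentage points higher from compound 1 to compound 2 (beyond the scatter) is the largest movement seen so far.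

Compound 3 `COc1cc(/C=C/C(=O)C2=C(/C=C/c3ccc(O)c(OC)c3)NC(=S)NC2c2ccc(C)cc2)ccc1O` gives 62%. How its core differs from the core of compound 1 is not broken down here; the two values show compound 3 above compound 1 and below compound 2.

Compound 4 `COc1cc(/C=C/C(=O)C2=C(/C=C/c3ccc(O)c(OC)c3)NC(=S)NC2c2ccccc2O)ccc1O` has not yet been measured. It relates to compound 3 through the change (2-hydroxyphenyl in place of 4-methylphenyl on a saturated ring carbon), which is the same change, at the same place, as that from compound 1 to compound 2. The expected step is therefore taken from that earlier one: a number 28 percentage points higher from compound 3 to compound 4 (beyond the scatter) is estimated on the strength of a number 42.9 percentage points higher from compound 1 to compound 2 (beyond the scatter), with the expected step held smaller than that earlier one because compound 3 already gives 62%. Compound 4 is expected to give 90%, estimated within 70% to 100%.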

Compound 4, a percentage reported as activity, at one concentration (the size of the read-out at that concentration, not a potency): 86.3%
Beside the measured number, compound 4's estimate is 3.7 percentage points above it, and the stated range covers the measured number.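

In this assay, 2-hydroxyphenyl in place of 4-methylphenyl on the saturated ring carbon again moves the read-out the same way on the second core, giving a number 24.3 percentage points higher from compound 3 to compound 4 (beyond the scatter). The direction of the change therefore carries across the two cores shown, but its size does not carry over unchanged: the same change on two cores in this assay, a number 42.9 percentage points higher (beyond the scatter) from compound 1 to compound 2 and a number 24.3 percentage points higher (beyond the scatter) from compound 3 to compound 4, 18.6 percentage points apart, beyond the scatter of two such steps These two pairs do not show why the sizes differ, and they do not show whether the change would behave alike on any other core.

The compounds shown leave open whether the hydroxyl itself accounts for the step, since a phenyl ring bearing a methoxy group, a fluorine or an amine in its place would be needed to separate this from the loss of the methyl group. Also open, going by these compounds, is whether the step persists when a shorter chain, such as ethyl, replaces the 2-(4-hydroxy-3-methoxyphenyl)ethenyl group on the ring.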